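Swapping a sulfonate for a ketone on a fused core

The compounds below may be only part of what the source reports. "The series", "measured", "known", "first", "only" and "open" are said of these compounds alone.

Compound 3, `Cc1ccc(S(=O)(=O)Oc2c(-c3ccccc3)c(-c3ccccc3)n3ccc(C#N)cc23)cc1`, is the reference point here. Going by the values given here, in an assay for inhibition of Polyunsaturated fatty acid lipoxygenase ALOX15 (Oryctolagus cuniculus) (a lower number here means a stronger inhibitor, a higher number a weaker inhibitor), compound 3 gives 25000 nM, the lowest of the two numbers known so far. Its nearest neighbour is compound 2, `N#Cc1ccn2c(-c3ccccc3)c(-c3ccccc3)c(Cc3ccccc3)c2c1`, which in this assay gives 46000 nM; the step of a 1.8-fold lower number from compound 2 to compound 3 (0.26 log units; within the scatter) is within the scatter, so the two compounds cannot be told apart on these numbers. Compound 1, `Cc1ccc(C(O)c2c(-c3ccccc3)c(-c3ccccc3)n3ccc(C#N)cc23)cc1`, has no result in this assay: for compound 1 the entry reads "not determined" (no result reported).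

Compound 4 is `N#Cc1ccn2c(-c3ccccc3)c(-c3ccccc3)c(C(=O)c3ccccc3)c2c1`. It differs from compound 3 in one place: benzoyl in place of ((4-methylphenyl)sulfonyl)oxy on an aromatic carbon. Among the compounds with values here, the only measured step that touches this aromatic carbon is a 1.8-fold lower number from compound 2 to compound 3 (0.26 log units; within the scatter), in which a benzyl and a ((4-methylphenyl)sulfonyl)oxy group gave numbers within the scatter of each other. Benzoyl is a further group at this aromatic carbon, and nothing in the two measured numbers suggests that what sits there moves the result much. I therefore expect compound 4 to land close to compound 3, with a step of a 1.2-fold higher number from compound 3 to compound 4 (0.08 log units; within the scatter) that stays within the scatter. My estimate for compound 4 in this assay is 30000 nM, with a range from 12000 nM to 75000 nM.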

Compound 4, half-maximal inhibitory concentration: 43000 nM
Compound 4: the middle estimate sits 1.4-fold (0.16 log units) below what was measured; the range from low to high includes it.
By their numbers in this assay, from the lowest: compounds 3, 4 and 2 (each within the scatter of the next).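

In this assay, benzoyl in place of ((4-methylphenyl)sulfonyl)oxy gives a 1.7-fold higher number from compound 3 to compound 4 (0.24 log units; within the scatter), and benzoyl in place of benzyl gives a 1.1-fold lower number from compound 2 to compound 4 (0.03 log units; within the scatter), so neither change at this aromatic carbon can be told apart from repeat-measurement noise. Three groups have now been compared here instead of two, and all three carry a six-membered aromatic ring of carbon only, joined to the shared core through a different link; on these numbers, swapping that link produces no readable difference, so the earlier impression from a single step now rests on compounds 2, 3 and 4 together. No measurement available here offers an explanation for this result.

As far as these compounds go, every group compared at this carbon still carries that aromatic ring, so it remains open how the number would respond to a group without one, such as an amine or a carboxylic acid. From the compounds shown here alone, it is also open whether a change elsewhere on the shared core, such as a carboxylic acid in place of the nitrile, would give a step beyond the scatter.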